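A few compounds are considered here, and "the series" means these few. Any claim that something is new, unique, unknown or untested is made for them only; others in the source may bear on it.

Measured in a functional assay on Ehrlich cells (Mus musculus) for cytotoxicity, read by trypan blue exclusion, with a stated time of 2 h, tested at 25 ug/mL; on this read-out lower numbers stand for a stronger effect and higher numbers for a weaker effect at the one concentration tested:
compound 1 `N#Cc1c(N)[n+]([O-])c2ccc(Cl)cc2[n+]1[O-]` gives 65.1%
compound 2 `CNc1c(C#N)[n+]([O-])c2cc(Cl)ccc2[n+]1[O-]` gives 90.6%

Among these two numbers compound 2 stands highest in this assay, and the nearest is compound 1 with the lower number; the step of a number 25.5 percentage points higher from compound 1 to compound 2 (beyond the scatter) lies beyond the scatter, so compound 2 is the weaker of the pair on this read-out. Compound 3 `CC(=O)N(C(C)=O)c1c(C#N)[n+]([O-])c2cc(Cl)ccc2[n+]1[O-]` differs from compound 2 by diacetylamino in place of methylamino on an aromatic carbon. Among the measured compounds shown here, the only measured step, a number 25.5 percentage points higher from compound 1 to compound 2 (beyond the scatter), alters the same nitrogen, but through a different replacement, so it does not cover this change directly. For the measured compounds named here, because compound 2 with 90.6% already sits near the top of the scale, little room remains for a further rise, and no measured step points downward. A step within the scatter is therefore expected, a number 0.6 percentage points lower from compound 2 to compound 3 (within the scatter). Compound 3 is estimated at 90%, between 70% and 100%.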

Compound 3, a percentage reported as activity, at one concentration (the size of the read-out at that concentration, not a potency): 3%
For compound 3 the middle estimate is 87 percentage points above the measured one; measured number outside the range, below it.
By their numbers in this assay, from the lowest: compound 3; then compound 1; then compound 2.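

At this aromatic carbon, the group attached through the nitrogen can change the result far more than the methyl step suggested: in this assay, diacetylamino gives a number 87.6 percentage points lower from compound 2 to compound 3 (beyond the scatter) and, starting from the amino compound, a number 62.1 percentage points lower from compound 1 to compound 3 (beyond the scatter) on the same read-out. Methyl moved the number up, whereas diacetylamino moves it far down, so changes here can act in either direction, and compound 3 shows the strongest effect of the three. No available evidence accounts for this drop.

As far as these compounds go, it remains open whether one acetyl group is enough, as a single acetylamino group would show, or whether both are needed. Dimethylamino, which carries two groups on the nitrogen but no carbonyl, could help separate having two groups there from having carbonyls.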